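Swapping Acetamidophenyl for Pyridinyl on a Shared Core

A few compounds are considered here, and "the series" means these few. Any claim that something is new, unique, unknown or untested is made for them only; others in the source may bear on it.

Of the compounds shown here, two built on the same core have been measured in an assay on CHO cells for displacement of a labelled ligand from 5-hydroxytryptamine receptor 1B (Homo sapiens); on this read-out lower numbers stand for stronger inhibition and higher numbers for weaker inhibition. Compound 1 `c1ccc(C2CCCCN2C2CCN(CCCc3c[nH]c4ccc(-n5cnnc5)cc34)CC2)cc1` gives 410 nM in this assay. Compound 2 `CC(=O)Nc1ccc(CNC2CCN(CCCc3c[nH]c4ccc(-n5cnnc5)cc34)CC2)cc1` gives 45 nM in this assay. Of the two numbers, compound 2 holds the lower one, and its gap to compound 1 lies beyond the usual scatter of repeated measurements, so compound 2 stands as the stronger binder of the pair.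

Compound 3 `c1cncc(CNC2CCN(CCCc3c[nH]c4ccc(-n5cnnc5)cc34)CC2)c1` has not yet been measured. It differs from compound 2 in one place: pyridin-3-yl in place of 4-acetamidophenyl on a saturated chain carbon bound to an amine nitrogen. Going by the values given here, no pair of measured compounds isolates this change, so its size cannot be read from the data at hand; what leaves is a larger group with one hydrogen-bond donor and one acceptor, what enters is a smaller group with one acceptor only. A moderate weakening is expected from compound 2 to compound 3, a step that may or may not exceed the scatter. In this assay compound 3 is estimated at 120 nM, within a range from 40 nM to 400 nM. That estimate corresponds to an expected step of a 2.7-fold higher number from compound 2 to compound 3 (0.43 log units; beyond the scatter).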

Compound 3, half-maximal inhibitory concentration: 140 nM
Compound 3: middle estimate off by 1.2-fold (0.07 log units), on the low side; the range from low to high includes it.
By their numbers in this assay, from the lowest: compound 2; then compound 3; then compound 1.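

In this assay the replacement of 4-acetamidophenyl by pyridin-3-yl on a saturated chain carbon bound to an amine nitrogen gives a 3.1-fold higher number from compound 2 to compound 3 (0.49 log units; beyond the scatter) and so provides the first measured size for a change at this position. The step lies beyond the usual scatter, which shows that binding responds to the group carried here, yet it remains modest even though the entering group has fewer heavy atoms than the group that leaves and has 0 hydrogen-bond donors against 1. No measurement at hand bears on the origin of this step, so it stands as an observed difference without an explanation.

The change alters the ring, the size of the group and the hydrogen-bond donor count all at once, so the compounds shown cannot divide the step among these differences. Going by these compounds, it remains open how a plain phenyl ring, or an acetamido group carried on the pyridine ring, would read at the same place, and whether either would fall closer to compound 2 or to compound 3.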